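Liver microsome stability across a benzofuran-bearing series

This account rests on a few compounds, and the source may have more. Where it says the series, first, only, none or still open, it means among the compounds named here.

Measured so far:
compound 1 `COc1nn2cc(-c3cc4ccccc4o3)nc2s1` — 31%
compound 2 `COc1cc(OCc2cccc(CCc3ccccc3)c2)c2cc(-c3cn4nc(OC)sc4n3)oc2c1` — 68%

Both values come from an ADME assay on microsomes from liver (Rattus norvegicus) for metabolic stability, with a stated time of 10 min; on this read-out higher numbers stand for a more stable compound and lower numbers for a less stable compound. Compound 2 stands highest of the two numbers; its nearest neighbour is compound 1, which in this assay gives 31%, a gap that lies beyond the usual scatter. Within the data shown here, no pair among the measured compounds differs in only one place, so no single step has been resolved, and what separates compound 1 from compound 2 is the sum of several changes.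

The next compound, compound 3 `COc1cc(OCc2cccc(O)c2)c2cc(-c3cn4nc(OC)sc4n3)oc2c1`, is not yet measured in this assay. It is compound 2 with one change: hydroxy in place of phenethyl on an aromatic carbon

Among the measured compounds shown here, no measured step covers this change. The expected step from compound 2 to compound 3 in this assay is a number 8 percentage points lower from compound 2 to compound 3 (within the scatter), a modest loss that may well fall within the scatter, with wide uncertainty in both directions. For compound 3 the estimate in this assay is 60%, with a range from 35% to 85%, anchored on compound 2 because compound 2 gives 68%.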

Compound 3, percent of the compound remaining: 49%
Compound 3: middle estimate off by 11 percentage points, on the high side, within the range that was stated.
By their numbers in this assay, from the lowest: compound 1; then compound 3; then compound 2.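

Working notes: the aromatic carbon meta to a large group is the one place in this series where a single change can be read so far. In this assay, hydroxy in place of phenethyl gives a number 19 percentage points lower from compound 2 to compound 3 (beyond the scatter), so the substituent at this position does move the read-out, although the step is modest. Compound 2 and compound 3 share everything else, which ties this step to this one exchange, but the evidence at hand offers no explanation for it, and a single step cannot separate what leaving phenethyl contributes from what entering hydroxy contributes.

The two groups seen at this position leave open where a methoxy group, an amine or a carboxylic acid would fall on this read-out. Also open, as far as these compounds go, is whether the higher number of compound 2 needs the whole phenethyl group, or whether a phenyl group directly on the ring, or a longer chain ending in phenyl, would serve as well.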